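Changing the amide group on a shared core

The source may report more compounds than this note shows. Statements on the series, on what has been measured and on what is new or still open speak of the compounds shown alone.

Compound 1 `O=C(Nc1cc(Sc2ncn[nH]2)c(O)c2ccccc12)c1ccc2ccccc2c1`: 45100 nM
Compound 2 `O=C(Nc1cc(Sc2ncnc3nc[nH]c23)c(O)c2ccccc12)c1ccc(Cl)cc1`: 23000 nM

Compound 1 was tested in a functional assay on MDA-MB-231 cells (Homo sapiens) for antiproliferative activity, read by MTT assay, with a stated time of 48 h (on this read-out lower numbers stand for stronger inhibition and higher numbers for weaker inhibition), where it gave 45100 nM. Compound 2, which carries a different amide and a different sulfur-linked ring on the same core, gave 23000 nM in this assay. These two numbers lie within the usual scatter of repeated measurements, so neither compound can be called the more active one; both sit in the region of weak inhibition.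

Compound 3 `O=C(/C=C/c1ccccc1)Nc1cc(Sc2ncn[nH]2)c(O)c2ccccc12` differs from compound 1 in a single spot: 2-phenylethenyl in place of naphthalen-2-yl on a carbonyl carbon. Among the measured compounds shown here, no pair of measured compounds shows what this kind of exchange does, so there is no measured step to lean on. Because compound 1 gives 45100 nM and compound 2 gives 23000 nM in the same weak region, the expectation is that compound 3 stays close to compound 1, with a step of a 1.1-fold lower number from compound 1 to compound 3 (0.05 log units; within the scatter) that is not expected to exceed the scatter in either direction. Compound 3 is therefore estimated at 40000 nM, with a range from 15000 nM to 120000 nM.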

Compound 3, half-maximal inhibitory concentration: > 100000 nM
Compound 3 ended at the assay's limit (the forecaster's own chance of this, stated with the estimate: 15%); middle value at least 2.5-fold (0.39 log units) from the limit.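

In this assay compound 3 gives > 100000 nM, which is a limit of the assay and not a number. Placing 2-phenylethenyl in place of naphthalen-2-yl on a carbonyl carbon gives an at least 2.2-fold higher number from compound 1 to compound 3 (0.34 log units; beyond the scatter), the first single-place comparison in this series, and it shows that activity in this assay depends on the group held at this position. The step can be read only in one direction, with no upper end to its size: the limit of > 100000 nM in this assay, at which 1 of the 3 values shown sits.

This exchange removes one six-membered aromatic ring and brings in a double bond outside aromatic rings at the same time, so the compounds shown cannot separate these two changes. Going by these compounds, how a saturated 2-phenylethyl group, or a phenyl ring carrying an amine or a carboxylic acid, would behave on this carbonyl carbon remains open.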